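Lengthening the hydroxamate chain: compound 2 to compound 3

The compounds below may be only part of what the source reports. "The series", "measured", "known", "first", "only" and "open" are said of these compounds alone.

Values in a functional assay on U-937 cells (Homo sapiens) for inhibition, read by MTT assay, with a stated time of 48 h; a higher number here means a weaker inhibitor, a lower number a stronger inhibitor:
- compound 1 `O=C(O)c1ccc2c(c1)no[n+]2[O-]`: "not determined" (no result reported)
- compound 2 `O=C(CCCCOC(=O)c1ccc2c(c1)no[n+]2[O-])NO`: 19900 nM

Among the measured compounds shown here, compound 2 holds the only number so far, so it cannot yet be ranked. Compound 1 has no result in this assay and offers no comparison.

The next compound is compound 3 `O=C(CCCCCCCOC(=O)c1ccc2c(c1)no[n+]2[O-])NO`. It keeps the shared core and the ester of compound 2 and differs only in the chain: 3-(hydroxycarbamoyl)propyl in place of hydroxycarbamoyl on a saturated chain carbon, four bonds along the chain from an oxygen next to a carbonyl group. In words, 3-(hydroxycarbamoyl)propyl stands in place of hydroxycarbamoyl on a saturated chain carbon, four bonds along the chain from an oxygen next to a carbonyl group.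

For the measured compounds named here, no measured pair shows what lengthening the chain does. The expected direction therefore rests on the structural change alone, and the range is kept wide. A moderate gain in inhibition is expected, with a step of a 6.6-fold lower number from compound 2 to compound 3 (0.82 log units; beyond the scatter) that would lie beyond the usual scatter in this assay. The estimated value for compound 3 is 3000 nM, with an expected range from 500 nM to 15000 nM.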

Compound 3, half-maximal inhibitory concentration: 11900 nM
Beside the measured number, compound 3's estimate is 4.0-fold (0.60 log units) below it; the range from low to high includes it.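

In this assay, among the compounds shown here, the first measured pair of the series gives a 1.7-fold lower number from compound 2 to compound 3 (0.22 log units; within the scatter) and so places compound 2 and compound 3 within the usual scatter of each other. At this position, on a saturated chain carbon, four bonds along the chain from an oxygen next to a carbonyl group, 3-(hydroxycarbamoyl)propyl in place of hydroxycarbamoyl therefore gives no number that can be told apart from the parent in this read-out, so this change of chain length shows no effect that can be resolved. No supporting measurement bears on this outcome.

Still open, from the compounds shown here alone, is whether a longer chain than the 3-(hydroxycarbamoyl)propyl group, or a chain with an aromatic ring built into it, would produce a step beyond the scatter. Going by these compounds, it is equally open whether the hydroxycarbamoyl end itself matters at this chain length, which a carboxylic acid or a primary amide at the same chain end would test against compound 3.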